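Swapping the benzyl on the sulfonyl of compound 1

This account rests on a few compounds, and the source may have more. Where it says the series, first, only, none or still open, it means among the compounds named here.

Measured compounds:
compound 1, `Cc1ccc(S(=O)(=O)Cc2ccccc2)cc1C#Cc1cc(Cl)ccc1OCC(=O)O`: 5 nM
compound 2, `CCCc1ccncc1C#Cc1cc(Cl)ccc1OCC(=O)O`: 4.3 nM
compound 3, `O=C(O)COc1cc(F)ccc1C#Cc1ccccc1Cl`: 4780 nM

All three were tested in an assay on CHO cells for displacement of a labelled ligand from prostaglandin D2 receptor 2 (Homo sapiens), read by scintillation counting; on this read-out lower numbers stand for stronger inhibition and higher numbers for weaker inhibition. Compound 1 gives 5 nM, the second highest of the three numbers. Its nearest neighbour is compound 2 with 4.3 nM, a gap that lies within the usual scatter of repeated measurements, so the two cannot be told apart. Compound 3, which carries a fluorine on its core and a chlorine on the other ring, gives 4780 nM, far beyond the scatter from both others.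

The step to be followed goes from compound 1 to compound 4, `Cc1ccc(S(=O)(=O)N(C)CCN(C)C)cc1C#Cc1cc(Cl)ccc1OCC(=O)O`. The change is (2-(dimethylamino)ethyl)(methyl)amino in place of benzyl on a sulfonyl sulfur. Cut one bond further out, it reads benzylsulfonyl to (2-(dimethylamino)ethyl)(methyl)sulfamoyl. Among the measured compounds shown here, no measured pair here shows this kind of change, so the size of the step cannot be read from the data; compound 2 shows only that a different group at this end of the molecule can still give a low number.

A small move to a higher number is expected, possibly not beyond the scatter, so that compound 4 is estimated at 15 nM with a range of 3 nM to 80 nM, meaning an expected step of a 3.0-fold higher number from compound 1 to compound 4 (0.48 log units; beyond the scatter).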

Compound 4, inhibition constant: 369 nM
Estimate against measurement, compound 4: 25-fold (1.39 log units) below; measured number outside the range, above it.
By their numbers in this assay, from the lowest: compounds 2 and 1 (each within the scatter of the next); then compound 4; then compound 3.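

In this assay, putting (2-(dimethylamino)ethyl)(methyl)amino in place of benzyl on a sulfonyl sulfur gives a 74-fold higher number from compound 1 to compound 4 (1.87 log units; beyond the scatter), a large move towards weaker inhibition. This shows that the group at this position strongly affects the result, and that matching its size by heavy-atom count is not enough to keep the low number of compound 1, since the leaving and entering groups have the same count. The data offer no explanation for the size of this step.

The step removes an aromatic ring of carbon and brings in a ringless chain with nitrogen atoms, so the compounds shown leave open which of these two differences matters. A benzylsulfamoyl group, which keeps the aromatic ring while adding a nitrogen on the sulfur, and a plain hexyl chain, which has neither a ring nor a nitrogen, would help to separate the two.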